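Toward an Estimate for Compound 4

The source may hold more compounds than are shown below. What is called first, only, known or untested is meant among the compounds shown, and "the series" means these compounds.

Measured so far in an ADME assay on L02 cells (Homo sapiens) for cytotoxicity, read by MTT assay, with a stated time of 24 h; a lower number here means a stronger inhibitor, a higher number a weaker inhibitor:
- compound 1 (`CN1C/C(=C\c2ccc(C#N)cc2)C(=O)/C(=C/c2cccnc2)C1`): > 20000 nM
- compound 2 (`CN1C/C(=C\c2ccncc2)C(=O)/C(=C/c2ccccc2C(F)(F)F)C1`): 15800 nM
- compound 3 (`O=C1/C(=C/c2cccnc2)CNC/C1=C\c1ccccc1F`): 15900 nM

Compound 1 reads > 20000 nM as a limit of the assay and not as a number. Among the compounds with values here, compound 3 gives 15900 nM and stands level with compound 2 at 15800 nM within the scatter, so these two provide the only numbers available.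

The next compound, compound 4 (`Cc1ccc(S(=O)(=O)N2C/C(=C\c3cccnc3)C(=O)/C(=C/c3ccccc3F)C2)cc1`), departs from compound 3 by one change: (4-methylphenyl)sulfonyl in place of hydrogen on an amine nitrogen in a ring. Here (4-methylphenyl)sulfonyl stands in place of hydrogen on an amine nitrogen in a ring.

Within the data shown here, no measured pair isolates this change, so its size in this assay remains an expectation with little support. A modest move toward a lower number is expected, though a result within the scatter of compound 3 would be no surprise. The estimated change is a 1.8-fold lower number from compound 3 to compound 4 (0.25 log units; within the scatter) in this reading. For compound 4 the expected value is 9000 nM, with an estimated range from 3000 nM to 20000 nM as its limits.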

Compound 4, half-maximal inhibitory concentration: 14900 nM
The estimate for compound 4 lay 1.7-fold (0.22 log units) below the measured number; the measured number falls inside the stated range.
By their numbers in this assay, from the lowest: compounds 4, 2 and 3 (each within the scatter of the next). At a limit, above all of these: compound 1.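

In this assay, within the data shown here, the first pair that isolates a change on the amine nitrogen in a ring gives a 1.1-fold lower number from compound 3 to compound 4 (0.03 log units; within the scatter), so with (4-methylphenyl)sulfonyl in place of hydrogen the two numbers cannot be told apart. The earlier compounds shown here carried only hydrogen or methyl on this nitrogen, and no pair among them isolated a change there. Compound 1 stands at a limit of this assay and not at a number: the limit of > 20000 nM in this assay, at which 1 of the 4 values shown sits.

This single step leaves open whether other groups on this nitrogen, such as an acetyl group, a longer alkyl chain or a carboxylic acid, would also stay within the scatter. Going by these compounds, it also remains open whether the same (4-methylphenyl)sulfonyl change would give so small a step with other aromatic groups on the shared core.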